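The compounds below may be only part of what the source reports. "The series", "measured", "known", "first", "only" and "open" are said of these compounds alone.

Compound 1 (`CCCOP(=O)(O)OCCSC(=S)N1CCCCC1`), compound 2 (`CCCCCCCCOP(=O)(O)OCCSC(=S)N1CCCCC1`), compound 3 (`CCCCCCCCCCOP(=O)(O)OCCSC(=S)N1CCN(C)CC1`) and compound 4 (`CCCCCCCCCCOP(=O)(O)OCCSC(=S)N1CCCCC1`) share a core and differ in their chain, in the group on the thiocarbonyl carbon, or in both. In a functional assay on MCF7 cells (Homo sapiens) for inhibition, read by MTT assay, with stated times of 18 h and 4 h (a lower number here means a stronger inhibitor, a higher number a weaker inhibitor), compound 1 gives > 100000 nM, which is a limit of the assay and not a number. Compound 2 gives 26000 nM and compound 3 gives 99600 nM. Compound 3 therefore has the higher of the two true numbers, and the gap to compound 2 lies beyond the scatter.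

Moving on to compound 4 keeps the chain of compound 3 and changes one place: piperidin-1-yl in place of 4-methylpiperazin-1-yl on a thiocarbonyl carbon. In words, piperidin-1-yl takes the place of 4-methylpiperazin-1-yl on a thiocarbonyl carbon.

For the measured compounds named here, no measured step makes this exact swap. The closest guide is an at least 3.8-fold lower number from compound 1 to compound 2 (0.58 log units; beyond the scatter), a lengthening of the chain with piperidin-1-yl in place. Compound 2, at 26000 nM, also carries piperidin-1-yl and sits lower than compound 3, although its chain differs as well, so this comparison is only indirect. On this basis, a lower number of modest size, beyond the scatter, is expected in this assay. The estimated step is a 5.5-fold lower number from compound 3 to compound 4 (0.74 log units; beyond the scatter). Compound 4 is expected at 18000 nM, with an estimated range from 6000 nM to 50000 nM.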

Compound 4, half-maximal inhibitory concentration: 7240 nM
Estimate against measurement, compound 4: 2.5-fold (0.40 log units) above; measured number inside the range.
By their numbers in this assay, from the lowest: compound 4; then compound 2; then compound 3. At a limit, above all of these: compound 1.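

In this assay, for the compounds shown here, the group on the thiocarbonyl carbon has a large effect on its own: with the decyl chain held fixed, piperidin-1-yl in place of 4-methylpiperazin-1-yl gives a 14-fold lower number from compound 3 to compound 4 (1.14 log units; beyond the scatter) and is the only change in that step. Going by these compounds alone, with piperidin-1-yl in place, the number continues to fall beyond the octyl chain of compound 2, as the decyl chain gives a 3.6-fold lower number from compound 2 to compound 4 (0.56 log units; beyond the scatter) and so extends the trend that the earlier compounds showed only from the propyl chain to the octyl chain. Compound 1 stands at a limit of the assay, so the step with the widest span in chain length, an at least 13-fold lower number from compound 1 to compound 4 (1.14 log units; beyond the scatter), gives only a bound and not an exact size: the limit of > 100000 nM in this assay, at which 1 of the 4 values shown sits.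

As far as these compounds go, whether 4-methylpiperazin-1-yl raises the number by a similar amount on an octyl or a propyl chain remains open, since the swap is seen here on the decyl chain alone. Also open, from the compounds shown here alone, are where a morpholin-4-yl group on the thiocarbonyl carbon would fall, and whether a dodecyl chain would lower the number further or reverse the trend.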